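The source may hold more compounds than are shown below. What is called first, only, known or untested is meant among the compounds shown, and "the series" means these compounds.

Among the compounds measured so far, compound 3 `O=C(NCc1ccccc1)c1cnc2ncccc2c1O` stands lowest: in an assay for binding affinity to adenosine receptor A1 (Bos taurus) (a lower number here means a stronger inhibitor, a higher number a weaker inhibitor), compound 3 gives 2750 nM. Compound 1 `Cc1ccc2c(O)c(C(=O)NCc3ccc(NC(=O)c4ccccc4)cc3)cnc2n1`, which carries a longer side chain on its amide, gives 7590 nM in this assay. Compound 2 `CC(=O)Nc1ccc2c(O)c(C(=O)NCc3ccccc3)cnc2n1` reaches only a limit of the assay, > 10000 nM, and no exact number. Going by the values given here, the one measured step that touches the place now of interest is an at least 3.6-fold lower number from compound 2 to compound 3 (0.56 log units; beyond the scatter); its size rests on (the limit of > 10000 nM in this assay, at which 1 of the 3 values shown sits), so it is known only as a minimum. Compound 4 `CN(C)c1ccc2c(O)c(C(=O)NCc3ccccc3)cnc2n1` differs from compound 3 by dimethylamino in place of hydrogen on an aromatic carbon. This is the place where compound 2 carries acetamido, and taking that group away gave the lower number of compound 3. Putting a different substituent there, one counted as having no hydrogen-bond donor, is therefore expected to move the number back upward from compound 3, though not necessarily as far as the limit seen for acetamido. The estimated change is a 2.4-fold higher number from compound 3 to compound 4 (0.37 log units; beyond the scatter). Compound 4 is expected to give about 6500 nM in this assay, with a likely range from 2500 nM to 20000 nM.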

Compound 4, inhibition constant: 122 nM
Compound 4: the middle estimate sits 53-fold (1.73 log units) above what was measured; the whole stated range lies above it.
By their numbers in this assay, from the lowest: compound 4; then compound 3; then compound 1. At a limit, above all of these: compound 2.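

In this assay, dimethylamino in place of hydrogen on this aromatic carbon, next to the ring nitrogen, gives a 23-fold lower number from compound 3 to compound 4 (1.35 log units; beyond the scatter), so a substituent here can lower the number well beyond that of the unsubstituted core. Exchanging acetamido for dimethylamino at the same place gives an at least 81-fold lower number from compound 2 to compound 4 (1.91 log units; beyond the scatter), which shows that the earlier gain on removing acetamido was no general penalty for any group at this position. Compound 2 stands at a limit, so this second step is known only as a minimum: the limit of > 10000 nM in this assay, at which 1 of the 4 values shown sits.

As far as these compounds go, it remains open whether the low number is particular to dimethylamino or would also come with a plain amino group, methylamino, methoxy or a ring amine such as pyrrolidine. The compounds shown also do not tell whether dimethylamino would have the same effect alongside the longer amide side chain of compound 1.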